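Shortening the selenocyanate link on the shared core

A few compounds are considered here, and "the series" means these few. Any claim that something is new, unique, unknown or untested is made for them only; others in the source may bear on it.

Of the compounds shown here, three on one core have been read in a functional assay on A549 cells (Homo sapiens) for inhibition, read by MTT assay, with a stated time of 48 h; on this read-out lower numbers stand for stronger inhibition and higher numbers for weaker inhibition. Compound 1 `COc1ccc(N(C)c2nc(C)nc3ccccc23)cc1OCCN` gives 122 nM. Compound 2 `COc1ccc(N(C)c2nc(C)nc3ccccc23)cc1C(=O)OCCCC[Se]C#N` gives 155 nM, and compound 3 `COc1ccc(N(C)c2nc(C)nc3ccccc23)cc1C[Se]C#N` gives 98 nM. Compound 3 stands on the lowest of the three numbers, but its steps to the other two do not leave the scatter: a 1.2-fold lower number from compound 1 to compound 3 (0.10 log units; within the scatter) and a 1.6-fold lower number from compound 2 to compound 3 (0.20 log units; within the scatter). Likewise a 1.3-fold higher number from compound 1 to compound 2 (0.10 log units; within the scatter).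

Compound 4 `COc1ccc(N(C)c2nc(C)nc3ccccc23)cc1[Se]C#N` is not yet measured. It differs from compound 3 in one place: a group of 3 heavy atoms (1 carbon, 1 nitrogen, 1 selenium; no ring) in place of a group of 4 heavy atoms (2 carbon, 1 nitrogen, 1 selenium; no ring), on an aromatic carbon.

For the measured compounds named here, two measured steps bear on this. Between compound 2 and compound 3 the same selenocyanate end was carried on chains of quite different length, and the result was a 1.6-fold lower number from compound 2 to compound 3 (0.20 log units; within the scatter), within the scatter. Between compound 1 and compound 3 a group of equal size but different make-up on the same aromatic carbon gave a 1.2-fold lower number from compound 1 to compound 3 (0.10 log units; within the scatter), also within the scatter. Changes at this aromatic carbon have so far not moved the number in this assay beyond the scatter, and no step beyond the scatter is expected here either. Compound 4 is therefore expected near 110 nM, with a range from 55 nM to 220 nM. The implied step, a 1.1-fold higher number from compound 3 to compound 4 (0.05 log units; within the scatter), is expected to remain within the scatter.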

Compound 4, half-maximal inhibitory concentration: 49 nM
Beside the measured number, compound 4's estimate is 2.2-fold (0.35 log units) above it; the measured number lies below the stated range.
By their numbers in this assay, from the lowest: compounds 4, 3, 1 and 2 (each within the scatter of the next, the first and the last beyond it).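

In this assay, for the compounds shown here, the group of 3 heavy atoms, on an aromatic carbon ortho to a methoxy group, gives the first steps at this position that lie beyond the scatter, both modest (a 3.2-fold lower number from compound 2 to compound 4 (0.50 log units; beyond the scatter); a 2.5-fold lower number from compound 1 to compound 4 (0.40 log units; beyond the scatter)). The direct step from the group of 4 heavy atoms remains within the scatter (a 2.0-fold lower number from compound 3 to compound 4 (0.30 log units; within the scatter)), so the loss of one carbon from the link is not resolved as a change on its own, and compound 4 separates only from compound 1 and compound 2. Nothing on hand gives a measured basis for these steps, and no cause can be assigned to them.

Open, going by these compounds, is whether selenium itself counts at this aromatic carbon: a thiocyanate or a plain nitrile in the same place would separate the selenium atom from the rest of the group. Also open, on these data alone, is whether the group of 3 heavy atoms gives a similar number on another aromatic carbon of the same ring, and whether the steps hold in a read-out other than this assay.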